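Compound 3 to compound 4: hydroxy removed from ring

The compounds below may be only part of what the source reports. "The series", "measured", "known", "first", "only" and "open" are said of these compounds alone.

Working notes on the series. Three compounds have numbers in an assay on Vas deferens with Adrenergic receptor alpha-1 (Rattus norvegicus) as the target; on this read-out lower numbers stand for tighter binding and higher numbers for weaker binding. Compound 1 `COc1cccc(OC)c1OCCNC[C@@H]1C[S@@+]([O-])c2ccccc2O1` gives 19.5 nM in this assay. Compound 2 `COc1cccc(OC)c1OCCNC[C@@H]1CSc2ccccc2C1=O` gives 1.29 nM in this assay, the lowest number of the three, with both other compounds beyond the scatter from it. Compound 3 `COc1cccc(OC)c1OCCNC[C@@H]1COc2ccccc2[C@@H]1O` gives 60.3 nM in this assay, the highest number of the three: the nearest number is that of compound 1, which is lower and beyond the scatter, and the furthest is that of compound 2, lower still. Compound 1 and compound 2 each differ from compound 3 in more than one place, so these gaps show only how far apart the three values lie.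

Compound 4 `COc1cccc(OC)c1OCCNC[C@@H]1COc2ccccc2C1` is not yet measured. It differs from compound 3 in one place: hydrogen in place of hydroxy on a saturated ring carbon. Going by the values given here, no pair of measured compounds in the set differs by this change, so no step can be read from the data. Because compound 3 gives 60.3 nM, the highest number in this assay, the expectation is a moderate move toward a lower number rather than none. The expected step is a 2.4-fold lower number from compound 3 to compound 4 (0.38 log units; beyond the scatter). Compound 4 is therefore estimated at 25 nM in this assay, within a range from 6 nM to 100 nM.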

Compound 4, dissociation constant: 10.7 nM
Compound 4: the middle estimate sits 2.3-fold (0.37 log units) above what was measured; the measured number falls inside the stated range.
By their numbers in this assay, from the lowest: compound 2; then compounds 4 and 1 (each within the scatter of the next); then compound 3.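

In this assay, the change from hydroxy to hydrogen on this saturated ring carbon gives a 5.6-fold lower number from compound 3 to compound 4 (0.75 log units; beyond the scatter), so the hydroxy at this position is not required for binding, and the compound without it binds more tightly. Going by these compounds alone, this is the first single-place comparison: the earlier values showed only how far apart compounds differing in more than one place lie, whereas this step ties a modest change, beyond the scatter, to one position on the ring. The data shown offer no measurement that accounts for the step.

From the compounds shown here alone, it remains open whether a methoxy group, a fluorine atom or an amine on this ring carbon would give a number closer to that of compound 3 or to that of compound 4, and whether the hydroxy in the opposite spatial arrangement would behave as it does in compound 3. Going by these compounds, it is equally open whether the same change would give a step of similar size on the core of compound 1 or the core of compound 2.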